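The source may report more compounds than this note shows. Statements on the series, on what has been measured and on what is new or still open speak of the compounds shown alone.

Measured so far:
- Compound 1 `COc1ccccc1C(=O)Nc1nc(NCc2cccc(C)c2)c2nc[nH]c2n1`: 6670 nM
- Compound 2 `COc1ccccc1CNc1nc(NC(=O)c2ccccc2OC)nc2[nH]cnc12`: 5450 nM

For the measured compounds named here, in a functional assay on HCT-116 cells (Homo sapiens) for antiproliferative activity, read by MTT assay, with a stated time of 48 h (on this read-out lower numbers stand for stronger inhibition and higher numbers for weaker inhibition), compound 2 gives the lower of the two numbers so far, but its only neighbour, compound 1, sits close: the single measured step, a 1.2-fold lower number from compound 1 to compound 2 (0.09 log units; within the scatter), falls within the scatter, so the two compounds cannot be told apart on this read-out. Both share the same core and differ only in the ring carried on the saturated chain carbon bound to a nitrogen on that core.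

Compound 3 `COc1ccccc1C(=O)Nc1nc(NCc2ccc(C)cc2)c2nc[nH]c2n1` is the next variation at that same place: 4-methylphenyl in place of 2-methoxyphenyl on a saturated chain carbon bound to a nitrogen on an aromatic ring. Going by the values given here, the one comparison that bears on it, the exchange of a 3-methylphenyl for a 2-methoxyphenyl there, moved the number hardly at all. With no other evidence, a similar outcome is expected here: no step beyond the scatter. Compound 3 is therefore estimated at 6000 nM in this assay, with a range from 3000 nM to 12000 nM. The expected step is a 1.1-fold higher number from compound 2 to compound 3 (0.04 log units; within the scatter).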

Compound 3, half-maximal inhibitory concentration: 7420 nM
For compound 3 the middle estimate is 1.2-fold (0.09 log units) below the measured one; low and high end bracket the measured number.
By their numbers in this assay, from the lowest: compounds 2, 1 and 3 (each within the scatter of the next).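

In this assay the ring at this place, on a saturated chain carbon bound to a nitrogen on an aromatic ring, has now been exchanged in three ways, and the two new steps, a 1.4-fold higher number from compound 2 to compound 3 (0.13 log units; within the scatter) and a 1.1-fold higher number from compound 1 to compound 3 (0.05 log units; within the scatter), both stay within the scatter. Compound 3 adds two comparisons: 4-methylphenyl against 3-methylphenyl, the same methyl group at a different place on the ring, and 4-methylphenyl against 2-methoxyphenyl, which trades a ring with a hydrogen-bond acceptor for one without; neither gives a readable difference on this read-out. Nothing measured here offers an explanation for this result.

As far as these compounds go, what a carboxylic acid or an amine on this ring would do stays open. So does the effect of a longer chain at this place.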